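The source may report more compounds than this note shows. Statements on the series, on what has been measured and on what is new or still open speak of the compounds shown alone.

Values in an in vivo ADME assay on the whole organism for pharmacokinetics, with Rattus norvegicus as the target (a higher number here means that more of the compound sits outside the plasma, a lower number that more of the compound stays in the plasma), so far
Compound 1 `O=C(Nc1cccnc1-c1ccsc1)N1CCN2C(=O)N([C@H]3C[C@@H]3c3ccccc3)C(=O)[C@@H]2C1` gives 10 L/kg
Compound 2 `O=C(Nc1cccnc1-c1cccc(Cl)c1)N1CCN2C(=O)N([C@H]3C[C@@H]3c3ccccc3)C(=O)[C@@H]2C1` gives 4.1 L/kg
Compound 3 `O=C(Nc1cccnc1-c1ccccc1)N1CCN2C(=O)N([C@H]3C[C@@H]3c3ccccc3)C(=O)[C@@H]2C1` gives 6.7 L/kg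

Among these three compounds, compound 3 at 6.7 L/kg falls inside the span set by the other two, and it cannot be told apart from either. The two steps that reach it are a 1.5-fold lower number from compound 1 to compound 3 (0.17 log units; within the scatter) and a 1.6-fold higher number from compound 2 to compound 3 (0.21 log units; within the scatter). Only the outer pair separates, with a 2.4-fold lower number from compound 1 to compound 2 (0.39 log units; beyond the scatter), a modest step.

Compound 4 `N#Cc1cccc(-c2ncccc2NC(=O)N2CCN3C(=O)N([C@H]4C[C@@H]4c4ccccc4)C(=O)[C@@H]3C2)c1` has not yet been measured in this assay. It differs from compound 3 by cyano in place of hydrogen on an aromatic carbon, so that phenyl becomes 3-cyanophenyl, with the cyano meta to a large group. Within the data shown here, the closest precedent is compound 2, which carries 3-chlorophenyl, and removing that chloro gave a 1.6-fold higher number from compound 2 to compound 3 (0.21 log units; within the scatter). Replacing the whole aryl group of compound 1 with phenyl gave a 1.5-fold lower number from compound 1 to compound 3 (0.17 log units; within the scatter). Neither step leaves the scatter, although the step to 3-chlorophenyl from compound 1, a 2.4-fold lower number from compound 1 to compound 2 (0.39 log units; beyond the scatter), does. Among the measured compounds shown here, a small fall is therefore the most that these compounds suggest, and the data hold no cyano example. The expected change is a 1.4-fold lower number from compound 3 to compound 4 (0.14 log units; within the scatter), which is not expected to exceed the scatter. Compound 4 is estimated at 4.8 L/kg, with an expected range of 2.5 L/kg to 9 L/kg.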

Compound 4, volume of distribution at steady state: 6 L/kg
Estimate against measurement, compound 4: 1.3-fold (0.10 log units) below; measured number inside the range.
By their numbers in this assay, from the lowest: compounds 2, 4, 3 and 1 (each within the scatter of the next, the first and the last beyond it).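

In this assay, cyano in place of hydrogen on this aromatic carbon gave a 1.1-fold lower number from compound 3 to compound 4 (0.05 log units; within the scatter), so the step from phenyl to 3-cyanophenyl could not be told from the scatter. Cyano in place of chloro gave a 1.5-fold higher number from compound 2 to compound 4 (0.17 log units; within the scatter), and 3-cyanophenyl in place of thiophen-3-yl gave a 1.7-fold lower number from compound 1 to compound 4 (0.22 log units; within the scatter), so compound 4 cannot be separated from any of the other three compounds, whereas 3-chlorophenyl in place of thiophen-3-yl gave a 2.4-fold lower number from compound 1 to compound 2 (0.39 log units; beyond the scatter), which lies beyond the scatter. Nothing among the data offers an explanation for these numbers.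

On this carbon the compounds shown carry only hydrogen, chloro and cyano, so they leave open whether a group of another kind, such as an amine, a carboxylic acid or a longer chain, would give a step beyond the scatter. They also hold no cyano on any other carbon of this ring, and no cyano on the thiophen-3-yl of compound 1, so what is seen here for cyano applies only to this one place on the phenyl ring.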